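Methyl on the Ring Amide Nitrogen in Two Series

The compounds below may be only part of what the source reports. "The series", "measured", "known", "first", "only" and "open" are said of these compounds alone.

Compound 1, `CN1C/C(=C\c2ccc(Cl)cc2)C(=O)[C@@]2(C1)[C@H](c1ccc(Cl)cc1)CN(C)[C@]21C(=O)Nc2ccccc21`: 61.5%
Compound 2, `CN1C/C(=C\c2ccc(Cl)cc2)C(=O)[C@@]2(C1)[C@H](c1ccc(Cl)cc1)CN(C)[C@]21C(=O)N(C)c2ccccc21`: 62%
Compound 3, `CN1C[C@@H](c2cccs2)[C@@]2(Cc3ccccc3C2=O)[C@@]12C(=O)Nc1ccccc12`: 10.9%

In a functional assay on RPMI18226 cells (Homo sapiens) for antiproliferative activity, read by sulforhodamine B assay, with a stated time of 48 h, tested at 10 uM (on this read-out higher numbers stand for more inhibition at the one concentration tested (going by the name of the read-out) and lower numbers for less inhibition), compound 1 gives 61.5%, and compound 2 gives 62%. Compound 2 differs from compound 1 by methyl in place of hydrogen on an amide-type nitrogen in a ring, and this gives a number 0.5 percentage points higher from compound 1 to compound 2 (within the scatter). Compound 3 rests on another core; the difference between the two cores is not broken down here. In this assay compound 3 gives 10.9%. Compound 4, `CN1C(=O)[C@@]2(c3ccccc31)N(C)C[C@@H](c1cccs1)[C@@]21Cc2ccccc2C1=O`, has not yet been measured. It differs from compound 3 by methyl in place of hydrogen on an amide-type nitrogen in a ring, the same kind of change as before, though here the ring is part of a fused or bridged system of five rings rather than four. Because the measured step of a number 0.5 percentage points higher from compound 1 to compound 2 (within the scatter) lay within the scatter, compound 4 is expected to show a step of about a number 1.1 percentage points higher from compound 3 to compound 4 (within the scatter). Compound 4 is therefore estimated at 12%, likely between 0% and 28%.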

Compound 4, a percentage reported as inhibition, at one concentration (the size of the read-out at that concentration, not a potency): 12.1%
For compound 4 the middle estimate is 0.1 percentage points below the measured one; low and high end bracket the measured number.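

Methyl in place of hydrogen on an amide-type nitrogen in a ring gives a number 1.2 percentage points higher from compound 3 to compound 4 (within the scatter) in this assay. Set beside the earlier step, the change reads the same on both cores: the same change on two cores in this assay, a number 0.5 percentage points higher (within the scatter) from compound 1 to compound 2 and a number 1.2 percentage points higher (within the scatter) from compound 3 to compound 4, 0.7 percentage points apart, within the scatter of two such steps This rests on two pairs at a single concentration, so it shows that the step carried over between these two cores, but it does not show that it would carry over to any other core, and it does not explain what separates the two cores themselves.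

Only hydrogen and methyl appear on that nitrogen in the compounds shown. As far as these compounds go, what an ethyl group, a longer chain or a chain ending in an amine would do there remains open.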